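This account rests on a few compounds, and the source may have more. Where it says the series, first, only, none or still open, it means among the compounds named here.

Measured in a functional assay on ACHN cells (Homo sapiens) for inhibition, read by colorimetric assay and sulforhodamine B assay, with a stated time of 48 h; a higher number here means a weaker inhibitor of growth, a lower number a stronger inhibitor of growth:
- compound 1 `CCCCCCCCCCCC[C@@H](O)[C@H]1CC[C@H]([C@H](O)CCCCCCCCCCNC(=O)c2ccco2)O1`: 100000 nM
- compound 2 `CCCCCCCCCCCC[C@@H](O)[C@H]1CC[C@H]([C@H](O)CCCCCCCCCCNC(=O)c2cncs2)O1`: 100000 nM
- compound 3 `CCCCCCCCCCCC[C@@H](O)[C@H]1CC[C@H]([C@H](O)CCCCCCCCCCNC(=O)c2ccsc2)O1`: 3890 nM

Compound 3, at 3890 nM, has the lowest number of the three and is the strongest inhibitor of growth in this small set, clearly ahead of both others. The next compound, compound 4 `CCCCCCCCCCCC[C@@H](O)[C@H]1CC[C@H]([C@H](O)CCCCCCCCCCNC(=O)c2ccnn2C)O1`, keeps the shared core and the amide but has 1-methyl-1H-pyrazol-5-yl in place of thiophen-3-yl on a carbonyl carbon.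

Going by the values given here, no measured step covers this ring directly, so the closest evidence comes from the other ring exchanges at the same place. Replacing furan-2-yl with thiophen-3-yl gave a 26-fold lower number from compound 1 to compound 3 (1.41 log units; beyond the scatter), a large step. Replacing 1,3-thiazol-5-yl with thiophen-3-yl gave a 26-fold lower number from compound 2 to compound 3 (1.41 log units; beyond the scatter), equally large. Exchanging furan-2-yl for 1,3-thiazol-5-yl gave no change at the digits printed from compound 1 to compound 2 (within the scatter). Thiophen-3-yl is thus the only ring of the three that gave a lower number, and leaving it has so far been seen only in reverse through these two steps. A move to a higher number is therefore expected, though perhaps not the full size of those steps, and the estimate is a 7.7-fold higher number from compound 3 to compound 4 (0.89 log units; beyond the scatter). For compound 4 the expected value in this assay is 30000 nM, within an estimated range of 6000 nM to 100000 nM.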

Compound 4, concentration for 50% growth inhibition: 24000 nM
Beside the measured number, compound 4's estimate is 1.3-fold (0.10 log units) above it; the range from low to high includes it.
By their numbers in this assay, from the lowest: compound 3; then compound 4; then compounds 1 and 2 (each within the scatter of the next).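

In this assay, 1-methyl-1H-pyrazol-5-yl on the carbonyl carbon shows that this position can give an intermediate level, not only the two levels seen before: the change from thiophen-3-yl gives a 6.2-fold higher number from compound 3 to compound 4 (0.79 log units; beyond the scatter), while the change from 1,3-thiazol-5-yl gives a 4.2-fold lower number from compound 2 to compound 4 (0.62 log units; beyond the scatter) and that from furan-2-yl gives a 4.2-fold lower number from compound 1 to compound 4 (0.62 log units; beyond the scatter). The ring exchange therefore now separates four compounds into three levels, with compound 3 still the strongest inhibitor of growth and compound 1 and compound 2 still level at the top of the numbers. Leaving thiophen-3-yl is now measured directly, and with this ring it gives up only part of the distance that separates compound 3 from compound 1 and compound 2.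

Nothing measured here accounts for these differences among the rings. The compounds shown leave open whether thiophen-2-yl or a phenyl ring on the same carbonyl carbon would give a number lower than that of compound 3, and whether the order of the rings would hold with a shorter chain in place of the one carrying the amide.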